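The source may report more compounds than this note shows. Statements on the series, on what has been measured and on what is new or still open speak of the compounds shown alone.

Measured compounds in a functional assay on QGY7701 cells (Homo sapiens) for cytotoxicity, read by MTT assay, with a stated time of 24 h; on this read-out higher numbers stand for weaker inhibition and lower numbers for stronger inhibition:
- compound 1 `C=CC1=C(C(=O)NC(C)(C)C)C(c2ccc(OC)cc2)OC1`: > 100000 nM, a limit of the assay
- compound 2 `C=CC1=C(C(=O)Nc2ccccc2OC)C(c2ccc(F)cc2)OC1`: 52800 nM
- compound 3 `C=CC1=C(C(=O)NC(C)(C)C)C(c2ccc(Cl)c(Cl)c2)OC1`: > 100000 nM, a limit of the assay

Compound 1 therefore stands at a limit rather than a number in this assay, and the limit of > 100000 nM in this assay, at which 2 of the 3 values shown sit, shows that compound 3 shares this limit; only compound 2 returns a measured value. Compound 4 `C=CC1=C(C(=O)Nc2ccccc2)C(c2ccc(OC)cc2)OC1` differs from compound 1 by phenyl in place of tert-butyl on an amide-type nitrogen. Among the measured compounds shown here, no step between measured compounds is available for this change, so the expected step from compound 1 to compound 4, an at least 1.2-fold lower number from compound 1 to compound 4 (0.09 log units; that floor lies within the scatter), is no more than a shift toward the weakly measurable range, as compound 2, an anilide, shows with 52800 nM. Compound 4 is expected to give 80000 nM, within 30000 nM to 200000 nM.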

Compound 4, half-maximal inhibitory concentration: > 100000 nM
Compound 4 ended at the assay's limit; the forecaster's own chance of this, stated with the estimate: 55%; at least 1.2-fold (0.09 log units) between middle value and limit.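

Compound 4, like compound 1, ends at a limit, so no step between the two can be read: the limit of > 100000 nM in this assay, at which 3 of the 4 values shown sit.

The compounds shown leave open whether phenyl in place of tert-butyl on an amide-type nitrogen changes the value at all.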